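A Chain on the Free Nitrogen of Compound 3

This account rests on a few compounds, and the source may have more. Where it says the series, first, only, none or still open, it means among the compounds named here.

Within the data shown here, in a functional assay on ECa-109 cells (Homo sapiens) for antiproliferative activity, read by MTT assay, with a stated time of 48 h (a lower number here means a stronger inhibitor, a higher number a weaker inhibitor), compound 3 `Cn1cc(C2=C(c3n[nH]c4ncccc34)C(=O)NC2=O)c2ccccc21` gives 46100 nM, the only true number available here. Compound 1 `Cn1cc(C2=C(c3nn(CCCn4cncn4)c4ncccc34)C(=O)NC2=O)c2ccccc21` gives > 100000 nM, which is a limit of the assay and not a number. Compound 2 `CN(C)CCCn1nc(C2=C(c3cn(C)c4ccccc34)C(=O)NC2=O)c2cccnc21` gives > 100000 nM, which is also a limit.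

Compound 4 `Cn1cc(C2=C(c3nn(CCn4ccnc4)c4ncccc34)C(=O)NC2=O)c2ccccc21` changes compound 3 in one place: 2-(1H-imidazol-1-yl)ethyl in place of hydrogen on an aromatic nitrogen. Here, 2-(1H-imidazol-1-yl)ethyl takes the place of hydrogen on an aromatic nitrogen.

Among the measured compounds shown here, two measured steps bear on this change, and both run in the opposite direction, from a chain to hydrogen. Replacing 3-(1H-1,2,4-triazol-1-yl)propyl with hydrogen gave an at least 2.1-fold lower number from compound 1 to compound 3 (0.33 log units; beyond the scatter). Replacing 3-(dimethylamino)propyl with hydrogen gave an at least 2.1-fold lower number from compound 2 to compound 3 (0.33 log units; beyond the scatter). Neither chain is the one entering here, so they offer only a guide. Read in reverse, they lead to the expectation of a higher number, meaning a weaker inhibitor, of similar or greater size, and the result may be only a limit.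

The expected change is a 2.2-fold higher number from compound 3 to compound 4 (0.34 log units; beyond the scatter). Compound 4 is estimated at 100000 nM, with an expected range of 45000 nM to 220000 nM.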

Compound 4, half-maximal inhibitory concentration: > 100000 nM
Compound 4 gave a limit, no number; the forecaster's own chance of this, stated with the estimate: 60%; the middle value sits exactly at the limit.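

In this assay, putting 2-(1H-imidazol-1-yl)ethyl on this aromatic nitrogen gave an at least 2.1-fold higher number from compound 3 to compound 4 (0.33 log units; beyond the scatter), so a chain with an ethyl link and an imidazole end behaves like the two propyl chains before it. Compound 4 gives > 100000 nM, which is a limit of the assay and not a number. All three chains shown on this nitrogen now go with a weaker result than the free nitrogen, with no compound against that pattern, yet the steps among compound 1, compound 2 and compound 4 cannot be read, so the chains cannot be ranked: the limit of > 100000 nM in this assay, at which 3 of the 4 values shown sit.

Still open, from the compounds shown here alone, is whether any group on this nitrogen keeps a readable number. A single methyl group, or a short chain ending in a carboxylic acid, would test whether the weakening holds beyond these three chains.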